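Swapping chloro for iodo on the compound 3 scaffold

The compounds below may be only part of what the source reports. "The series", "measured", "known", "first", "only" and "open" are said of these compounds alone.

Compound 1 `Cc1ccc(-c2nnc(C3=C(Cl)c4cc(C)c(C)cc4CCC3)o2)cc1`: 3880 nM
Compound 2 `Cc1cc2c(cc1C)C(Cl)=C(c1nnc(-c3ccc(F)cc3)o1)CCC2`: 520 nM
Compound 3 `Cc1cc2c(cc1C)C(Cl)=C(c1nnc(-c3cccc(Cl)c3)o1)CCC2`: 4570 nM

These three values come from a functional assay on PANC-1 cells (Homo sapiens) for antiproliferative activity, read by sulforhodamine B assay, with a stated time of 48 h; on this read-out higher numbers stand for weaker inhibition of growth and lower numbers for stronger inhibition of growth. Compound 3 sits level with compound 1, as shown by a 1.2-fold higher number from compound 1 to compound 3 (0.07 log units; within the scatter). Compound 2 stands apart, with an 8.8-fold higher number from compound 2 to compound 3 (0.94 log units; beyond the scatter).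

Compound 4 `Cc1cc2c(cc1C)C(Cl)=C(c1nnc(-c3cccc(I)c3)o1)CCC2` has not yet been measured. It carries iodo in place of chloro on an aromatic carbon, meta to a large group: iodo in place of chloro on an aromatic carbon.

Among the measured compounds shown here, no measured step makes this exact swap, so the evidence is indirect. Changing the group on this outer phenyl ring can matter, as a 7.5-fold lower number from compound 1 to compound 2 (0.87 log units; beyond the scatter) shows, yet the change to 3-chlorophenyl in compound 3 gave only a 1.2-fold higher number from compound 1 to compound 3 (0.07 log units; within the scatter). Both of the larger steps involve compound 2 and its 4-fluorophenyl group, which compound 4 does not carry. No shift beyond the scatter is therefore expected, although a wide margin is needed on both sides. The expected step is a 1.1-fold lower number from compound 3 to compound 4 (0.06 log units; within the scatter). For compound 4 the estimated value is 4000 nM, with an expected range of 1300 nM to 12000 nM.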

Compound 4, concentration for 50% growth inhibition: 4120 nM
Estimate against measurement, compound 4: 1.0-fold (0.01 log units) below, within the range that was stated.
By their numbers in this assay, from the lowest: compound 2; then compounds 1, 4 and 3 (each within the scatter of the next).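

In this assay, among the compounds shown here, the swap of 3-chlorophenyl to 3-iodophenyl gives the first direct comparison of two halogens at this position, and the result stays within the scatter (a 1.1-fold lower number from compound 3 to compound 4 (0.05 log units; within the scatter)). The 3-iodophenyl group also sits level with the 4-methylphenyl group (a 1.1-fold higher number from compound 1 to compound 4 (0.03 log units; within the scatter)). Compound 2 with its 4-fluorophenyl group stays apart from this new compound as well (a 7.9-fold higher number from compound 2 to compound 4 (0.90 log units; beyond the scatter)), so among these four compounds only compound 2 stands out.

No measured property of these compounds offers an account of why chloro and iodo read alike here. Still open, going by these compounds, is whether an amine or a carboxylic acid in place of the iodo would shift the number, and whether the gain seen with 4-fluorophenyl would carry over to other changes on the core.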